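Methyl for chloro on a well-tolerated uracil ether

A few compounds are considered here, and "the series" means these few. Any claim that something is new, unique, unknown or untested is made for them only; others in the source may bear on it.

Measured compounds:
compound 1, `Cc1c(Oc2ccccc2OCCn2ccc(=O)[nH]c2=O)cc(Cl)c2ccc(C#N)cc12`: > 100000 nM
compound 2, `Cc1cc(Oc2ccccc2OCCn2ccc(=O)[nH]c2=O)c(Cl)c2cc(C#N)ccc12`: > 100000 nM

Two compounds have been run in a toxicity assay on MT2 cells (Homo sapiens) for cytotoxicity, read by MTT assay; a higher number here means that more compound is tolerated, a lower number that less compound is tolerated. Compound 1 `Cc1c(Oc2ccccc2OCCn2ccc(=O)[nH]c2=O)cc(Cl)c2ccc(C#N)cc12` gives > 100000 nM in this assay, which is a limit of the assay and not a number. Compound 2 `Cc1cc(Oc2ccccc2OCCn2ccc(=O)[nH]c2=O)c(Cl)c2cc(C#N)ccc12` gives > 100000 nM in this assay, again a limit of the assay rather than a number. Compound 2 thus stands where every value shown stands, at the limit of > 100000 nM in this assay, at which 2 of the 2 values shown sit. Among the compounds with values here, no step between two measured compounds is available, so nothing measured tells how a single change moves this read-out.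

Compound 3 `Cc1cc(Oc2ccccc2OCCn2ccc(=O)[nH]c2=O)c(C)c2cc(C#N)ccc12` has not been measured. It differs from compound 2 in one place: methyl in place of chloro on an aromatic carbon. Within the data shown here, both measured compounds sit at the same limit, and no measured step covers a change of this kind, so the expected step is none beyond the scatter, a step that the limit leaves unreadable from compound 2 to compound 3. Compound 3 is expected to give 150000 nM in this assay, within a range of 50000 nM to 500000 nM, and most probably once more only a limit.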

Compound 3, half-maximal cytotoxic concentration: > 100000 nM
Compound 3 ended at the assay's limit (the forecaster's own chance of this, stated with the estimate: 80%); the middle value is on the limit's open side.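

In this assay compound 3 gives > 100000 nM which is a limit of the assay and not a number. Compound 1 and compound 2 also stand at a limit, so no step from either of them to compound 3 can be read: the limit of > 100000 nM in this assay, at which 3 of the 3 values shown sit.

The compounds shown leave open how much compound is actually tolerated and whether any single change, methyl in place of chloro included, moves this read-out.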